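Adding a Methyl Group Next to the Ring Nitrogen

A few compounds are considered here, and "the series" means these few. Any claim that something is new, unique, unknown or untested is made for them only; others in the source may bear on it.

Two compounds have been measured in a functional assay on HeLa cells (Homo sapiens) for cytotoxicity, read by MTT assay, with a stated time of 72 h, tested at 100 uM; on this read-out lower numbers stand for less inhibition of growth and higher numbers for more inhibition of growth at the one concentration tested:

compound 1, `N/C(=N\NC(=S)N1CCOCC1)c1ccccn1`: 87.2%
compound 2, `N/C(=N\NC(=S)N1CCCCC1)c1ccccn1`: 86%

Compound 2 holds the lower of the two numbers, and its nearest neighbour is compound 1, separated by a number 1.2 percentage points lower from compound 1 to compound 2 (within the scatter). That step concerns the group on the thiocarbonyl carbon, where piperidin-1-yl replaces morpholin-4-yl.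

Compound 3, `Cc1cccc(/C(N)=N/NC(=S)N2CCCCC2)n1`, differs from compound 2 at another place: methyl in place of hydrogen on an aromatic carbon. For the measured compounds named here, no measured step touches this ring, so the only guidance is the one measured step, which lay within the scatter. On that basis compound 3 is expected to show no step beyond the scatter, a number 2 percentage points lower from compound 2 to compound 3 (within the scatter). The estimate for compound 3 is therefore 84%, with a range from 65% to 95%.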

Compound 3, percent growth inhibition at one concentration: 85.4%
Beside the measured number, compound 3's estimate is 1.4 percentage points below it; the measured number falls inside the stated range.
By their numbers in this assay, from the lowest: compounds 3, 2 and 1 (each within the scatter of the next).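

In this assay, the change of methyl in place of hydrogen on an aromatic carbon, next to the ring nitrogen, is the first one shown on this ring, whereas the earlier step concerned only the group on the thiocarbonyl carbon. It gives a number 0.6 percentage points lower from compound 2 to compound 3 (within the scatter), so at the one concentration tested this ring position accepts a methyl group with no difference that can be told from the scatter. No measurement at hand bears on why the step is this small.

The compounds shown leave open whether a group other than methyl at this place, such as an amine, a carboxylic acid or a longer chain, would stay equally close to compound 2. They also leave open whether a methyl group on any other carbon of this ring would do the same.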